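The compounds below may be only part of what the source reports. "The series", "measured", "known", "first", "only" and "open" are said of these compounds alone.

The measured compounds are:
compound 1 `Cn1c(-c2ccccc2)nc2c(NC3CCCC3)ncnc21`, which gives 8510 nM in a functional assay on CHO cells for antagonist activity at adenosine receptor A2b (Homo sapiens), read by 33P incorporation, with a stated time of 20 min; a lower number here means a stronger inhibitor, a higher number a weaker inhibitor;
compound 2 `Cn1c(-c2cccnc2)nc2c(NC3CCCC3)ncnc21`, whose value in this assay is a limit of the assay, > 30000 nM;
compound 3 `Cn1c(-c2ccccc2)nc2c(NC3CCCCC3)ncnc21`, whose value in this assay is likewise a limit of the assay, > 30000 nM.

Going by the values given here, compound 1 thus stands as the only compound with a number; the other two sit at the limit of > 30000 nM in this assay, at which 2 of the 3 values shown sit. Both measured steps start from compound 1 and run towards weaker inhibition: an at least 3.5-fold higher number from compound 1 to compound 2 (0.54 log units; beyond the scatter), and an at least 3.5-fold higher number from compound 1 to compound 3 (0.54 log units; beyond the scatter).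

Compound 4 `CCCn1c(-c2ccccc2)nc2c(NC3CCCC3)ncnc21` differs from compound 1 by ethyl in place of hydrogen on a saturated chain carbon bound to an aromatic nitrogen. Neither measured step touches this position; one changes the aromatic group, the other the ring on the nitrogen, so neither bears directly on the chain on the aromatic nitrogen. They only show that the core of compound 1 gives up inhibition readily in two other places. Among the compounds with values here, no step in the data speaks to the change in compound 4, so no direction beyond the scatter is expected. Compound 4 is estimated at 6000 nM in this assay, within 1500 nM to 25000 nM, which means an expected step of a 1.4-fold lower number from compound 1 to compound 4 (0.15 log units; within the scatter).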

Compound 4, inhibition constant: 3430 nM
For compound 4 the middle estimate is 1.7-fold (0.24 log units) above the measured one, within the range that was stated.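

The saturated chain carbon bound to an aromatic nitrogen is the only place among those shown where a change strengthens inhibition in this assay: ethyl in place of hydrogen, which reads as methyl to propyl when cut one bond further out, gives a 2.5-fold lower number from compound 1 to compound 4 (0.39 log units; beyond the scatter). Both earlier steps from compound 1 ran towards weaker inhibition, so the core of compound 1 does not lose inhibition with every change. The step is modest, and nothing shown gives a cause for it.

The compounds shown leave open whether a longer chain such as butyl, or a chain ending in an amine or a carboxylic acid, would strengthen inhibition further at this place. They also leave open whether propyl here would give a measurable number when combined with the pyridin-3-yl of compound 2 or the cyclohexyl of compound 3.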